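A few compounds are considered here, and "the series" means these few. Any claim that something is new, unique, unknown or untested is made for them only; others in the source may bear on it.

Measured compounds:
compound 1 `CC1CCN(Cc2ccc3nc(NC(=O)N/N=C/c4cn(Cc5cccc(Cl)c5)c5ccccc45)sc3c2)CC1`: 2110 nM
compound 2 `CC1CCN(Cc2ccc3nc(NC(=O)N/N=C/c4cn(Cc5ccccc5Cl)c5ccccc45)sc3c2)CC1`: 1360 nM

Of the compounds shown here, two have been tested in a functional assay on MDA-MB-231 cells (Homo sapiens) for cytotoxicity, read by MTT assay, with a stated time of 72 h; on this read-out higher numbers stand for weaker inhibition and lower numbers for stronger inhibition. Compound 1 gives 2110 nM and compound 2 gives 1360 nM. The two differ only in where the chlorine sits on the phenyl ring, and the step of a 1.6-fold lower number from compound 1 to compound 2 (0.19 log units; within the scatter) shows that this change did not move the number beyond the usual scatter. Compound 2 therefore stands with the numerically smaller of the two results, but the two values cannot be told apart with confidence.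

Compound 3 `Cc1ccc(Cn2cc(/C=N/NC(=O)Nc3nc4ccc(CN5CCC(C)CC5)cc4s3)c3ccccc32)cc1` has not yet been measured. Compared with compound 2, the change is 4-methylphenyl in place of 2-chlorophenyl on a saturated chain carbon bound to an aromatic nitrogen. Among the compounds with values here, the only measured step, from compound 1 to compound 2, concerns the same phenyl ring, but it only moved the chlorine and was within the scatter. Within the data shown here, no measured step replaces the chlorine by a methyl group, so the effect of that part of the change is unknown. The expectation for compound 3 is thus a step of a 1.3-fold higher number from compound 2 to compound 3 (0.12 log units; within the scatter), with no change beyond the scatter, and the estimated value is 1800 nM, with a range from 700 nM to 4500 nM.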

Compound 3, half-maximal inhibitory concentration: 1140 nM
Compound 3: the middle estimate sits 1.6-fold (0.20 log units) above what was measured; the measured number falls inside the stated range.
By their numbers in this assay, from the lowest: compounds 3, 2 and 1 (each within the scatter of the next).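

Moving from a chlorophenyl to 4-methylphenyl on a saturated chain carbon bound to an aromatic nitrogen gives, in this assay, a 1.2-fold lower number from compound 2 to compound 3 (0.08 log units; within the scatter) and also a 1.9-fold lower number from compound 1 to compound 3 (0.27 log units; within the scatter) on the same read-out. The earlier pair only showed the chlorine moving around the ring, whereas these steps show that a ring with a methyl group and no chlorine at all also gives a number that cannot be told apart from those of the two chlorinated compounds. No measurement is available to explain why these numbers stay so close.

All three groups are phenyl rings with a single substituent, and the compounds shown leave open what happens with something different in kind at this position, such as a pyridine ring, a phenyl ring carrying a carboxylic acid or an amine, or a longer chain between the ring and the aromatic nitrogen. From the compounds shown here alone, every number here also comes from this assay alone, so whether the three compounds would stay this close on any other read-out remains unknown.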